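Lengthening the Chain One Carbon Further

The compounds below may be only part of what the source reports. "The series", "measured", "known", "first", "only" and "open" are said of these compounds alone.

Compound 3 `CN(C)C(=O)c1cc2cnc(Nc3ccc(C(=O)NCCCCCCN=C=S)cc3)nc2n1C1CCCC1` shares its core with compound 1 `CN(C)C(=O)c1cc2cnc(Nc3ccc(C(=O)NCCCN=C=S)cc3)nc2n1C1CCCC1` and compound 2 `CN(C)C(=O)c1cc2cnc(Nc3ccc(C(=O)NCCCCCN=C=S)cc3)nc2n1C1CCCC1`; the three differ only in the length of one saturated chain. In a functional assay on NCI-H1299 cells (Homo sapiens) for inhibition, read by CCK-8 assay, with a stated time of 72 h, tested at 10 uM (a lower number here means a weaker effect, a higher number a stronger effect of the compound at the concentration tested), compound 3 gives 85%. Compound 1 gives 91.2% and compound 2 gives 76.5%, so compound 3 sits close to both, since a number 6.2 percentage points lower from compound 1 to compound 3 (within the scatter) and a number 8.5 percentage points higher from compound 2 to compound 3 (within the scatter) stay within the scatter. Compound 4 `CN(C)C(=O)c1cc2cnc(Nc3ccc(C(=O)NCCCCCCCN=C=S)cc3)nc2n1C1CCCC1` extends the chain again: a group of 4 heavy atoms (2 carbon, 1 nitrogen, 1 sulfur; no ring) in place of a group of 3 heavy atoms (1 carbon, 1 nitrogen, 1 sulfur; no ring), on a saturated chain carbon, six bonds along the chain from an amide-type nitrogen. The earlier chain extensions bear on this step: a number 14.7 percentage points lower from compound 1 to compound 2 (beyond the scatter) was a modest loss, yet the other two changes showed nothing real, so no consistent direction emerges. A step within the scatter is therefore expected, a number 3 percentage points lower from compound 3 to compound 4 (within the scatter). Compound 4 is estimated at 82%, with a range from 70% to 92%.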

Compound 4, a percentage reported as inhibition, at one concentration (the size of the read-out at that concentration, not a potency): 107%
Compound 4: the middle estimate sits 25 percentage points below what was measured; the measured number lies above the stated range.
By their numbers in this assay, from the lowest: compounds 2, 3 and 1 (each within the scatter of the next, the first and the last beyond it); then compound 4.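

Here the chain extension produces a real gain for the first time: a number 22 percentage points higher from compound 3 to compound 4 (beyond the scatter). Compound 4 also stands clear of the other two shorter chains, with a number 30.5 percentage points higher from compound 2 to compound 4 (beyond the scatter) and a number 15.8 percentage points higher from compound 1 to compound 4 (beyond the scatter), so it has the strongest effect of the four at the concentration tested. Chain length still gives no steady trend, as a number 14.7 percentage points lower from compound 1 to compound 2 (beyond the scatter) goes against any simple rise with length.

Nothing available explains the jump. On these data alone, it remains open whether a longer chain, or a chain carrying an amine, would keep this effect.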